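Swapping an aryl group on a piperazine: predicting compound 4

The source may report more compounds than this note shows. Statements on the series, on what has been measured and on what is new or still open speak of the compounds shown alone.

Measured compounds:
Compound 1 `COc1ccccc1N1CCN(C(=O)C2(C)CCc3c(C)c(O)c(C)c(C)c3O2)CC1` gives 15000 nM in a functional assay (brain) for inhibition, with Rattus norvegicus as the target; a lower number here means a stronger inhibitor, a higher number a weaker inhibitor.
Compound 2 `Cc1c(C)c2c(c(C)c1O)CCC(C)(C(=O)N1CCN(c3ccccn3)CC1)O2` gives 1000 nM in this assay.
Compound 3 `COc1ccccc1N1CCN(CC2(C)CCc3c(C)c(O)c(C)c(C)c3O2)CC1` gives 1000 nM in this assay.

Compound 2 arises from compound 1 by one change, (pyridin-2-yl in place of 2-methoxyphenyl on an amine nitrogen in a ring), and this brought a 15-fold lower number from compound 1 to compound 2 (1.18 log units; beyond the scatter). Compound 3 shares the same aryl group as compound 1, but its core differs from the core of compound 1 in a way that is not broken down here. In this assay compound 3 and compound 2 stand level, and both lie well away from compound 1.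

Compound 4 `Cc1c(C)c2c(c(C)c1O)CCC(C)(CN1CCN(c3ccccn3)CC1)O2` has not yet been measured. Within the data shown here, it differs from compound 3 by pyridin-2-yl in place of 2-methoxyphenyl on an amine nitrogen in a ring, which is the same change as the one from compound 1 to compound 2, made at the same place. The step from compound 3 to compound 4 in this assay is therefore expected to go the same direction, estimated at a 4.0-fold lower number from compound 3 to compound 4 (0.60 log units; beyond the scatter), though somewhat smaller than a 15-fold lower number from compound 1 to compound 2 (1.18 log units; beyond the scatter) because compound 3 already starts from 1000 nM. Compound 4 is estimated at 250 nM, between 60 nM and 1000 nM.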

Compound 4, half-maximal inhibitory concentration: 1000 nM
Estimate against measurement, compound 4: 4.0-fold (0.60 log units) below; measured number inside the range.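

Putting pyridin-2-yl in place of 2-methoxyphenyl did not carry over from one core to the other: in this assay the same swap gave no change at the digits printed from compound 3 to compound 4 (within the scatter). Set side by side, the two steps clearly disagree: the same change on two cores in this assay, a 15-fold lower number (1.18 log units; beyond the scatter) from compound 1 to compound 2 and no change at the digits printed (within the scatter) from compound 3 to compound 4, 15-fold (1.18 log units) apart, beyond the scatter of two such steps. This shows that, for these two pairs, the result of the swap depends on the core it is made on, so a step measured on one core cannot simply be copied to the other; it does not show which feature of the cores is responsible, and one pair on each core cannot say how the swap would behave on any further core.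

The compounds shown leave open how other aryl groups, such as phenyl or pyrimidin-2-yl, would behave on each of the two cores. Also open, from the compounds shown here alone, is what the swap would do on a core with a longer chain leading to the ring nitrogen.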